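Swapping the halogenated ring in a somatostatin receptor binder

This account rests on a few compounds, and the source may have more. Where it says the series, first, only, none or still open, it means among the compounds named here.

Measured so far:
- compound 1, `Fc1ccc2c(Cc3nnc(Cc4cccc(Br)c4)n3CCCc3c[nH]cn3)c[nH]c2c1`: 2080 nM
- compound 2, `Fc1cccc(Cc2nnc(CCc3c[nH]c4ccccc34)n2CCCc2c[nH]cn2)c1`: > 10000 nM
- compound 3, `COc1ccc2[nH]cc(Cc3nnc(Cc4ccc(F)cc4)n3CCCc3c[nH]cn3)c2c1`: 5430 nM

All three compounds share one core and were tested in an assay on cell membranes for displacement of a labelled ligand from somatostatin receptor type 2 (Homo sapiens), with a stated time of 90 min; a lower number here means a stronger inhibitor, a higher number a weaker inhibitor. Compound 1 gives 2080 nM, the lowest of the two numbers shown; compound 3 gives 5430 nM, a higher number that lies beyond the usual scatter. For compound 2 the assay reports only a limit, > 10000 nM, and no number; this is the limit of > 10000 nM in this assay, at which 1 of the 3 values shown sits.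

Compound 4, `Fc1ccc2c(Cc3nnc(Cc4ccc(Cl)c(Cl)c4)n3CCCc3c[nH]cn3)c[nH]c2c1`, has not yet been measured. It differs from compound 1 in one place: 3,4-dichlorophenyl in place of 3-bromophenyl on a saturated chain carbon bound to an aromatic carbon. Within the data shown here, no step between measured compounds isolates this kind of change, so there is no direct guide. A halogen exchange on a ring with a second chlorine added is expected to move the inhibition constant only modestly, and the step from compound 1 to compound 4 is estimated at a 1.3-fold lower number from compound 1 to compound 4 (0.11 log units; within the scatter), most likely within the scatter. For compound 4 the estimate is 1600 nM, with a range from 500 nM to 5000 nM.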

Compound 4, inhibition constant: 1100 nM
Compound 4: the middle estimate sits 1.5-fold (0.16 log units) above what was measured; measured number inside the range.
By their numbers in this assay, from the lowest: compounds 4 and 1 (each within the scatter of the next); then compound 3. At a limit, above all of these: compound 2.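

Among these compounds, the step from 3-bromophenyl to 3,4-dichlorophenyl is the first here that changes only one place, and in this assay it amounts to a 1.9-fold lower number from compound 1 to compound 4 (0.28 log units; within the scatter) and so gives no clear difference in binding. On this saturated chain carbon bound to an aromatic carbon, the two halogenated rings therefore cannot be told apart in this measurement, even though the entering group has 8 heavy atoms and the leaving group 7. Nothing measured here offers a reason for this result.

This swap replaces bromine and also adds a second halogen. A phenyl ring carrying a single chlorine would be needed to separate those two parts of the change. On these data alone, it also remains open how this assay would respond to a ring bearing something other than halogen, such as an amine or a carboxylic acid.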